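Hydrazone series: aryl ring in place of alkyl chain

The compounds below may be only part of what the source reports. "The series", "measured", "known", "first", "only" and "open" are said of these compounds alone.

Three hydrazones on a shared core have been measured in an assay on CHO-K1 cells for displacement of a labelled ligand from adenosine receptor A1 (Homo sapiens), read by scintillation counting, with a stated time of 60 min; a lower number here means a stronger inhibitor, a higher number a weaker inhibitor. Compound 1 `CSCC/C=N/Nc1nc(N)c2ncn([C@@H]3O[C@H](CO)[C@@H](O)[C@H]3O)c2n1` carries a 2-(methylsulfanyl)ethyl group on the carbon double-bonded to nitrogen; in this assay compound 1 reaches only the limit of > 10000 nM, which is a limit of the assay rather than a number. Compound 2 `Nc1nc(N/N=C/c2cccnc2Cl)nc2c1ncn2[C@@H]1O[C@H](CO)[C@@H](O)[C@H]1O` gives 4.6 nM. Compound 3 `Nc1nc(N/N=C/c2ccc(Br)cn2)nc2c1ncn2[C@@H]1O[C@H](CO)[C@@H](O)[C@H]1O` gives 4.7 nM. The step of an at least 2100-fold lower number from compound 1 to compound 2 (3.33 log units; beyond the scatter) and the step of an at least 2100-fold lower number from compound 1 to compound 3 (3.32 log units; beyond the scatter) are both large, and both rest on the limit (the limit of > 10000 nM in this assay, at which 1 of the 3 values shown sits). The step of a 1.0-fold higher number from compound 2 to compound 3 (0.01 log units; within the scatter) lies within the scatter, so compound 2 and compound 3 are not separated. Compound 3 holds the higher of the two numbers, with compound 2 nearest.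

Compound 4 `Nc1nc(N/N=C/c2ccc(N3CCCC3)cc2)nc2c1ncn2[C@@H]1O[C@H](CO)[C@@H](O)[C@H]1O` differs from compound 3 by 4-(pyrrolidin-1-yl)phenyl in place of 5-bromopyridin-2-yl on a carbon with a double bond to nitrogen. The steps of an at least 2100-fold lower number from compound 1 to compound 2 (3.33 log units; beyond the scatter) and an at least 2100-fold lower number from compound 1 to compound 3 (3.32 log units; beyond the scatter) show a large drop when an aromatic ring replaces the chain at this carbon; the step of a 1.0-fold higher number from compound 2 to compound 3 (0.01 log units; within the scatter) shows that two different aromatic rings there sit within the scatter of each other. Compound 4 keeps an aromatic ring at that place, so in this assay no step beyond the scatter is firmly expected, though a modest rise is allowed for the larger group. Compound 4 is therefore estimated at 15 nM, with a range from 3 nM to 80 nM. The expected step is a 3.2-fold higher number from compound 3 to compound 4 (0.50 log units; beyond the scatter).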

Compound 4, inhibition constant: 5.1 nM
Compound 4: the middle estimate sits 2.9-fold (0.47 log units) above what was measured; low and high end bracket the measured number.
By their numbers in this assay, from the lowest: compounds 2, 3 and 4 (each within the scatter of the next). At a limit, above all of these: compound 1.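

The carbon with a double bond to nitrogen takes 4-(pyrrolidin-1-yl)phenyl, with its added five-membered non-aromatic ring, in place of 5-bromopyridin-2-yl, and this assay gives a 1.1-fold higher number from compound 3 to compound 4 (0.04 log units; within the scatter). The comparison with the other pyridine group gives the same reading, a 1.1-fold higher number from compound 2 to compound 4 (0.04 log units; within the scatter), so among these compounds a six-membered aromatic ring of carbon only is not separated from one with a hetero atom, and the larger group brings no step beyond the scatter. The step of an at least 1900-fold lower number from compound 1 to compound 4 (3.29 log units; beyond the scatter) is large, and its starting point is a limit and not a number: the limit of > 10000 nM in this assay, at which 1 of the 4 values shown sits.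

The only non-aromatic group shown at this carbon is 2-(methylsulfanyl)ethyl, so the compounds do not tell whether the large steps follow from the aromatic ring itself or from the loss of that particular chain, and a cyclohexyl ring or a plain hexyl chain would bear on this. As far as these compounds go, it also stays open whether the absence of any separation extends to a five-membered aromatic ring such as furan-2-yl, or to a phenyl ring carrying a carboxylic acid.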